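Changing the Group on the Ring Nitrogen

The source may report more compounds than this note shows. Statements on the series, on what has been measured and on what is new or still open speak of the compounds shown alone.

Three compounds with a shared core have been measured in a functional assay on CHO cells with adenosine receptor A1 (Homo sapiens) as the target, read by cAMP accumulation and immunoassay, with a stated time of 6 min, tested at 0.1 uM; on this read-out higher numbers stand for a weaker effect at the one concentration tested and lower numbers for a stronger effect:

compound 1, `Nc1scc(CN2CCN(c3ccc(F)cc3Cl)CC2)c1C(=O)c1ccc(Cl)cc1`, gives -6.2%
compound 2, `Nc1scc(CN2CCN(c3ccc(Cl)cc3F)CC2)c1C(=O)c1ccc(Cl)cc1`, gives -9.4%
compound 3, `Nc1scc(CN2CCN(c3cccc4ccccc34)CC2)c1C(=O)c1ccc(Cl)cc1`, gives 0%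

All three numbers sit close to zero, so none of the compounds shows a clear effect at the one concentration tested. Compound 1 has the second highest number of the three, but its neighbours lie within the scatter: a number 3.2 percentage points lower from compound 1 to compound 2 (within the scatter) and a number 6.2 percentage points higher from compound 1 to compound 3 (within the scatter). The two compounds 2 and 3 likewise differ only within the scatter, a number 9.4 percentage points higher from compound 2 to compound 3 (within the scatter).

Compound 4, `Nc1scc(CN2CCN(c3ccccc3F)CC2)c1C(=O)c1ccc(Cl)cc1`, has not yet been measured. It differs from compound 1 in one place: 2-fluorophenyl in place of 2-chloro-4-fluorophenyl on an amine nitrogen in a ring. The three measured steps all change the group on this same ring nitrogen, and all stay within the scatter, so no step beyond the scatter is expected here either, a number 1.2 percentage points higher from compound 1 to compound 4 (within the scatter). Compound 4 is therefore expected to give about -5%, with a likely range from -20% to 10%.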

Compound 4, a percentage reported as activity, at one concentration (the size of the read-out at that concentration, not a potency): -1%
Beside the measured number, compound 4's estimate is 4 percentage points below it; the range from low to high includes it.
By their numbers in this assay, from the lowest: compounds 2, 1, 4 and 3 (each within the scatter of the next).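

In this assay, among the compounds shown here, this is the first step on the ring nitrogen that changes a single atom: hydrogen in place of chloro on an aromatic carbon gives a number 8.4 percentage points higher from compound 2 to compound 4 (within the scatter). The larger swaps to 2-fluorophenyl also stay within the scatter, with a number 5.2 percentage points higher from compound 1 to compound 4 (within the scatter) when it replaces 2-chloro-4-fluorophenyl and a number 1 percentage points lower from compound 3 to compound 4 (within the scatter) when it replaces naphthalen-1-yl. So among these compounds, the chloro can be replaced by hydrogen, and a single 2-fluorophenyl ring can stand in place of naphthalen-1-yl, without a step beyond the scatter.

Going by these compounds, it remains open whether a different kind of group on this nitrogen, such as a benzyl group or a phenyl ring carrying a carboxylic acid or an amine, would give a step beyond the scatter. No evidence on the cause of these close numbers is at hand.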